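The compounds below may be only part of what the source reports. "The series", "measured", "known", "first", "only" and "open" are said of these compounds alone.

Measured in a functional assay on MCF7 cells (Homo sapiens) for cytotoxicity, read by MTT assay, with a stated time of 72 h; a lower number here means a stronger inhibitor, a higher number a weaker inhibitor:
Compound 1, `Cc1cccc(CSc2cc(Cl)c(C)cc2S(=O)(=O)/N=C(\N)n2nccc2-c2ccccc2)c1`, gives 47000 nM.
Compound 2, `Cc1cccc(CSc2cc(Cl)c(C)cc2S(=O)(=O)/N=C(\N)n2nc(C)cc2-c2ccccc2)c1`, gives 105000 nM.
Compound 3, `Cc1ccc(CSc2cc(Cl)c(C)cc2S(=O)(=O)/N=C(\N)n2nccc2-c2ccccc2)cc1`, gives 21000 nM.

Compound 2 has the highest number of the three, so it is the weakest inhibitor here; its steps to compound 1 and to compound 3 are both beyond the scatter. Compound 4, `Cc1cc(-c2ccccc2)n(/C(N)=N/S(=O)(=O)c2cc(C)c(Cl)cc2SCc2ccccc2Cl)n1`, differs from compound 2 in one place: 2-chlorophenyl in place of 3-methylphenyl on a saturated chain carbon bound to a sulfur. For the measured compounds named here, the only measured step at that position is a 2.2-fold lower number from compound 1 to compound 3 (0.35 log units; beyond the scatter), a modest change with a different entering group. The step of a 2.2-fold higher number from compound 1 to compound 2 (0.35 log units; beyond the scatter) concerns another position and does not bear on this change. Going by the values given here, with no close precedent, only a modest shift in either direction is expected. Compound 4 is therefore estimated at 70000 nM, within 25000 nM to 200000 nM, an expected step of a 1.5-fold lower number from compound 2 to compound 4 (0.18 log units; within the scatter).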

Compound 4, half-maximal inhibitory concentration: 135000 nM
Compound 4: middle estimate off by 1.9-fold (0.29 log units), on the low side; measured number inside the range.
By their numbers in this assay, from the lowest: compound 3; then compound 1; then compounds 2 and 4 (each within the scatter of the next).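

In this assay, putting 2-chlorophenyl in place of 3-methylphenyl on the saturated chain carbon bound to a sulfur gives a step within the scatter (a 1.3-fold higher number from compound 2 to compound 4 (0.11 log units; within the scatter)). Compounds 2 and 4 therefore cannot be told apart here, so this position does not respond to every change of group, although the earlier step there lay beyond the scatter (a 2.2-fold lower number from compound 1 to compound 3 (0.35 log units; beyond the scatter)). Nothing measured here explains this result.

Still open, from the compounds shown here alone, is whether an amine or a carboxylic acid on the phenyl group, or a longer chain in its place, would shift the number beyond the scatter.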